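The source may hold more compounds than are shown below. What is called first, only, known or untested is meant among the compounds shown, and "the series" means these compounds.

Compound 1 `CCCCCCCCCCCCCCC[C@@H](O)[C@@H](N)[C@@H](C)O` gives 18000 nM in a functional assay on WiDr cells (Homo sapiens) for antiproliferative activity, read by sulforhodamine B assay, with a stated time of 48 h; on this read-out higher numbers stand for weaker inhibition of growth and lower numbers for stronger inhibition of growth. Compound 2 `CCCCCCCCC[C@@H](O)[C@H](C)N` gives 17000 nM.

Compound 2 has the lowest of the two numbers, with compound 1 nearest and within the scatter. Compound 3 `CCCCCCCCCCCCCCC[C@@H](O)[C@H](C)N` is not yet measured; it differs from compound 2 by hexyl in place of hydrogen on a saturated chain carbon, ten or more bonds along the chain from an oxygen on a saturated carbon. Going by the values given here, no measured pair shows this step. Since compound 1, which carries a chain of comparable length, gives 18000 nM close to compound 2, the step of a 1.1-fold lower number from compound 2 to compound 3 (0.03 log units; within the scatter) is expected to stay within the scatter. Compound 3 is therefore estimated at 16000 nM, with a range from 6000 nM to 45000 nM.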

Compound 3, concentration for 50% growth inhibition: 700 nM
Compound 3: the middle estimate sits 23-fold (1.36 log units) above what was measured, outside the stated range (below it).
By their numbers in this assay, from the lowest: compound 3; then compounds 2 and 1 (each within the scatter of the next).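

In this assay, hexyl in place of hydrogen on a saturated chain carbon, ten or more bonds along the chain from an oxygen on a saturated carbon, brings a 24-fold lower number from compound 2 to compound 3 (1.39 log units; beyond the scatter) and so shows that this position responds strongly to the change. Compound 1 carries the same long chain, yet methyl in place of 1-hydroxyethyl on a saturated chain carbon bound to an amine nitrogen and a saturated chain carbon brings a 26-fold lower number from compound 1 to compound 3 (1.41 log units; beyond the scatter) in the same assay, so the hexyl step depends on that other site. The compounds shown leave open whether a longer chain, or a carboxylic acid at the chain end, would keep this gain. No evidence at hand bears on the reason for either step.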